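From phenyl to amino on the shared core

This account rests on a few compounds, and the source may have more. Where it says the series, first, only, none or still open, it means among the compounds named here.

- compound 1 `COc1cc2ncnc(-n3nc(-c4cccnc4)nc3N)c2cc1OC` gives > 71000 nM as a limit
- compound 2 `COc1cc2ncnc(-n3nc(-c4ccccc4)nc3N)c2cc1OC` gives > 50000 nM as a limit

In an ADME assay on BJ cells (Homo sapiens) for cytotoxicity, with a stated time of 72 h (a higher number here means that more compound is needed for the effect, a lower number that less compound is needed), compound 2 stands at > 50000 nM as a limit of the assay and not a number. Compound 1 gives > 71000 nM as a limit too. So no exact value exists yet for either compound.

Compound 3 `COc1cc2ncnc(-n3nc(N)nc3N)c2cc1OC` differs from compound 2 in one place (amino in place of phenyl on an aromatic carbon) on an aromatic carbon of a five-membered aromatic ring with 3 nitrogen, and the rest of the core stays the same.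

Going by the values given here, the one measured step (a step that the two limits leave unreadable from compound 1 to compound 2) also swaps a group on an aromatic carbon, but its size cannot be read, so it offers no size to carry over. In this assay no step beyond the scatter is therefore expected in either direction, and another limit is the likeliest report. The estimated step is a step that the limit leaves unreadable from compound 2 to compound 3 and it rests only on these two limits. For compound 3 the estimate is 60000 nM with an expected range from 25000 nM to 100000 nM if a number is reported at all.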

Compound 3, half-maximal effective concentration: > 33000 nM
Compound 3: a limit, no number (the forecaster's own chance of this, stated with the estimate: 75%); the middle value is on the limit's open side.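

In this assay compound 3 gives > 33000 nM, a limit and not a number. Compound 1 and compound 2 also stand at limits, and the steps from each of them to compound 3 cannot be read. The compounds shown leave open whether pyridin-3-yl, phenyl or amino on that aromatic carbon changes the concentration needed for the effect.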